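Cleaving the Benzyl Ester of Compound 2

The compounds below may be only part of what the source reports. "The series", "measured", "known", "first", "only" and "open" are said of these compounds alone.

Measured compounds:
compound 1, `N=C(N)NCCC[C@H](NC(=O)CN(c1nc(Cl)nc2[nH]cnc12)C1CC1)C(=O)OCc1ccccc1`, 30.4%
compound 2, `CC(C)[C@H](NC(=O)CN(c1nc(Cl)nc2[nH]cnc12)C1CC1)C(=O)OCc1ccccc1`, 51.3%
compound 3, `NC(=O)C[C@H](NC(=O)CN(c1nc(Cl)nc2[nH]cnc12)C1CC1)C(=O)OCc1ccccc1`, 32.3%

In a functional assay on the whole organism (Tail, strain ICR) with Mus musculus as the target, in the tail flick test, with a stated time of 90 min, at a dose of 25 umol/kg by the oral route (a higher number here means a stronger effect of the compound at the dose given, a lower number a weaker effect), compound 2 stands highest of the three numbers. Its nearest neighbour is compound 3, with a number 19 percentage points lower from compound 2 to compound 3 (beyond the scatter), and the furthest is compound 1, with a number 20.9 percentage points higher from compound 1 to compound 2 (beyond the scatter). Both of these steps exchange the group on a saturated chain carbon bound to an amide-type nitrogen and a carbonyl carbon; they leave the benzyloxycarbonyl end untouched.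

Compound 4, `CC(C)[C@H](NC(=O)CN(c1nc(Cl)nc2[nH]cnc12)C1CC1)C(=O)O`, differs from compound 2 at that other end: hydrogen in place of benzyl on an oxygen next to a carbonyl group. Going by the values given here, none of the measured steps concerns the ester oxygen, so no step in this assay can be carried over to this change. The expectation therefore rests on compound 2 alone and carries wide uncertainty. Compound 4 is expected to come out somewhat lower than compound 2, as a number 13.3 percentage points lower from compound 2 to compound 4 (beyond the scatter), though a result within the scatter is also plausible. The estimate for compound 4 is 38%, with a range from 10% to 60%.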

Compound 4, a percentage reported as activity, at one dose (the size of the read-out at that dose, not a potency): 30.3%
Beside the measured number, compound 4's estimate is 7.7 percentage points above it; measured number inside the range.
By their numbers in this assay, from the lowest: compounds 4, 1 and 3 (each within the scatter of the next); then compound 2.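

In this assay, the change from benzyl to hydrogen on the oxygen next to a carbonyl group gives a number 21 percentage points lower from compound 2 to compound 4 (beyond the scatter). Going by these compounds alone, the earlier steps exchanged only the group on the saturated chain carbon, so this is the first sign that the benzyloxycarbonyl end also bears on the read-out at this dose, at least with the isopropyl group in place. Nothing measured here explains why the number falls with the loss of benzyl. Within the data shown here, the single pair cannot separate the loss of the benzyl group from the change of ester to carboxylic acid, and a methyl ester, an ethyl ester or a primary amide at this end would help to tell the two apart. From the compounds shown here alone, whether the same change would carry over to the compounds with other chain groups also remains open.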